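This account rests on a few compounds, and the source may have more. Where it says the series, first, only, none or still open, it means among the compounds named here.

Compound 1, `Clc1ccccc1CSc1nnc(-c2ccncc2)n1-c1ccccc1`, gives 18100 nM in a functional assay on MCF7 cells (Homo sapiens) for inhibition, read by MTT assay, with a stated time of 48 h; a lower number here means a stronger inhibitor, a higher number a weaker inhibitor.
Compound 2, `Brc1ccccc1CSc1nnc(-c2ccncc2)n1-c1ccccc1`, gives 16100 nM in this assay.
Compound 3, `Fc1ccc(CSc2nnc(-c3ccncc3)n2-c2ccccc2)c(F)c1`, gives 14100 nM in this assay.

All three measured compounds share one core and differ only in the halogens on the ring that hangs off the sulfur. Compound 2 sits in the middle of the three numbers: the step of a 1.1-fold lower number from compound 1 to compound 2 (0.05 log units; within the scatter) and the step of a 1.1-fold lower number from compound 2 to compound 3 (0.06 log units; within the scatter) are both small, and so is a 1.3-fold lower number from compound 1 to compound 3 (0.11 log units; within the scatter), so none of the three can be set apart from the others.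

Compound 4, `c1ccc(CSc2nnc(-c3ccncc3)n2-c2ccccc2)cc1`, has not yet been measured in this assay. It differs from compound 2 by hydrogen in place of bromo on an aromatic carbon. Among the measured compounds shown here, no measured pair removes a halogen outright, so the evidence is indirect: swapping one halogen pattern for another left the numbers unchanged in every measured step. On that basis no step beyond the scatter is expected in this assay, though the direction remains uncertain and a modest weakening would not surprise.

Compound 4 is therefore estimated at 18000 nM in this assay, with a range from 8000 nM to 45000 nM.

The expected step is a 1.1-fold higher number from compound 2 to compound 4 (0.05 log units; within the scatter).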

Compound 4, half-maximal inhibitory concentration: 22400 nM
The estimate for compound 4 lay 1.2-fold (0.09 log units) below the measured number, and the stated range covers the measured number.
By their numbers in this assay, from the lowest: compounds 3, 2, 1 and 4 (each within the scatter of the next).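

Earlier steps only swapped one halogen pattern for another, whereas compound 4 has no halogen on this ring, which allows a direct test of whether one is needed here. In this assay, hydrogen in place of bromo gives a 1.4-fold higher number from compound 2 to compound 4 (0.14 log units; within the scatter) and hydrogen in place of chloro gives a 1.2-fold higher number from compound 1 to compound 4 (0.09 log units; within the scatter), while phenyl in place of 2,4-difluorophenyl gives a 1.6-fold higher number from compound 3 to compound 4 (0.20 log units; within the scatter) as the largest of these steps. All three stay within the scatter, so these compounds show no sign that a halogen matters on this ring, and nothing available offers an explanation for this result.

As far as these compounds go, whether a different kind of group on this ring, such as an amine or a carboxylic acid, would move the number beyond the scatter remains open. So does the effect of a longer chain in place of the single saturated carbon bound to the sulfur.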